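This account rests on a few compounds, and the source may have more. Where it says the series, first, only, none or still open, it means among the compounds named here.

Compound 1 `Cc1ccc(Cl)cc1N1CCN(c2ncnc3[nH]ncc23)CC1` and compound 2 `Cc1ccc(Cl)cc1N1CCN(c2ncnc3[nH]nc(C(C)C)c23)CC1` share one core and were both tested in an assay for inhibition of ribosomal protein S6 kinase beta-1 variant D18H,T412E (Homo sapiens), read by a luciferase reporter and chemiluminescence, with a stated time of 3 h (on this read-out higher numbers stand for weaker inhibition and lower numbers for stronger inhibition), where compound 1 gives 13 nM and compound 2 gives 16 nM. Among the measured compounds shown here, the only measured step, a 1.2-fold higher number from compound 1 to compound 2 (0.09 log units; within the scatter), puts isopropyl in place of hydrogen on an aromatic carbon. Compound 2 therefore stands with the highest of the two numbers, but its separation from compound 1 is inside the scatter, so no order between them can be read. Compound 3 `CCCc1n[nH]c2ncnc(N3CCN(c4cc(Cl)ccc4C)CC3)c12` is not yet measured; it differs from compound 2 by propyl in place of isopropyl on an aromatic carbon. The step from compound 1 to compound 2 bears on this change, since it showed that a three-carbon group at this carbon left the number essentially unchanged. A shift between two three-carbon groups at the same place is therefore expected to lie within the scatter as well, with the estimated step of a 1.1-fold lower number from compound 2 to compound 3 (0.03 log units; within the scatter). For compound 3 the estimate in this assay is 15 nM, ranging from 7 nM to 35 nM.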

Compound 3, half-maximal inhibitory concentration: 6 nM
Compound 3: the middle estimate sits 2.5-fold (0.40 log units) above what was measured; the measured number lies below the stated range.
By their numbers in this assay, from the lowest: compound 3; then compounds 1 and 2 (each within the scatter of the next).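

In this assay, the way the atoms of the group at this carbon are joined proves to matter: propyl in place of isopropyl, with the same atoms joined differently, gives a real change (a 2.7-fold lower number from compound 2 to compound 3 (0.43 log units; beyond the scatter)). The earlier step from hydrogen to isopropyl stayed within the scatter, which suggested that this carbon had little effect on the number, but propyl in place of hydrogen goes beyond it (a 2.2-fold lower number from compound 1 to compound 3 (0.34 log units; beyond the scatter)), so a group at this carbon can lower the number, if only modestly. Nothing available here accounts for the difference between propyl and isopropyl.

The compounds shown leave open whether butyl, a longer chain, would lower the number further or raise it again. They also leave open how an amine carried on the chain would compare with propyl.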